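Ring substitution pattern shift in an aryl glycoside series

The source may hold more compounds than are shown below. What is called first, only, known or untested is meant among the compounds shown, and "the series" means these compounds.

Among the measured compounds shown here, compound 1 `CO[C@H]1O[C@H](COc2ccc(-c3ccccc3)cc2)[C@@H](O)[C@H](O)[C@H]1Oc1ccccc1C(C)C` is the only member of the series with a number in a functional assay on A549 cells (Homo sapiens) for cytotoxicity, read by MTT assay, with a stated time of 48 h; on this read-out higher numbers stand for an effect only at larger amounts of compound and lower numbers for an effect already at smaller amounts. In this assay compound 1 gives 33000 nM. Compound 2 `CO[C@@H]1O[C@H](COc2ccc(-c3ccccc3)cc2)[C@@H](O)[C@H](O)[C@H]1Oc1ccccc1` belongs to the same set, but its result in this assay is "not determined" (no result reported), so it adds nothing to the numerical picture. Compound 3 `CO[C@H]1O[C@H](COc2ccc(-c3ccccc3)cc2)[C@@H](O)[C@H](O)[C@H]1Oc1cccc(C(C)C)c1` has not yet been tested. It differs from compound 1 in one place: 3-isopropylphenyl in place of 2-isopropylphenyl on an oxygen on a saturated carbon. The two compounds hold the same atoms, joined differently, and the change sits on an oxygen on a saturated carbon of the shared core. For the measured compounds named here, no pair of measured compounds shows how a change of this kind moves the read-out in this assay, so any expectation rests on compound 1 alone. Without such a reference, a step no larger than the usual scatter is expected, in no fixed direction, which is estimated as a 1.1-fold lower number from compound 1 to compound 3 (0.04 log units; within the scatter). Compound 3 is accordingly expected to give 30000 nM, with a range from 12000 nM to 80000 nM. A result returned only as a limit of the assay cannot be ruled out for compound 3.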

Compound 3, half-maximal effective concentration: 32000 nM
Compound 3: the middle estimate sits 1.1-fold (0.03 log units) below what was measured; measured number inside the range.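

In this assay the series now has its first readable step at this position: 3-isopropylphenyl in place of 2-isopropylphenyl on an oxygen on a saturated carbon gives a 1.0-fold lower number from compound 1 to compound 3 (0.01 log units; within the scatter). With the same atoms joined differently, these two placements of the isopropyl group on the phenyl ring cannot be told apart in this read-out, a finding that holds for this one pair on the shared core and that compound 1 alone could not provide. No supporting data bear on this result.

The compounds shown leave open whether this position responds to any group other than an isopropylphenyl, such as a phenyl ring carrying a primary amine, a carboxylic acid or a longer chain such as hexyl in place of the isopropyl group. They also leave open what the isopropyl group itself contributes, as compound 2 carries a plain phenyl but has no number in this assay and differs from compound 1 in more than one place.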